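The source may report more compounds than this note shows. Statements on the series, on what has been measured and on what is new or still open speak of the compounds shown alone.

Values in a functional assay on HeLa cells (Homo sapiens) for inhibition, read by sulforhodamine B assay (on this read-out higher numbers stand for weaker inhibition and lower numbers for stronger inhibition), so far:
- compound 1 `O=C1C(Nc2ccc(I)cc2)=CC(=O)c2c1nc1n2[C@H]2OC[C@@H](O)[C@H]2OC1` gives 4010 nM
- compound 2 `O=C1C(Nc2ccc(Br)cc2)=CC(=O)c2c1nc1n2[C@H]2OC[C@@H](O)[C@H]2OC1` gives 5220 nM
- compound 3 `COc1ccccc1NC1=CC(=O)c2c(nc3n2[C@H]2OC[C@@H](O)[C@H]2OC3)C1=O` gives 7460 nM

The three values form one group: a 1.4-fold higher number from compound 2 to compound 3 (0.16 log units; within the scatter) and a 1.9-fold higher number from compound 1 to compound 3 (0.27 log units; within the scatter) both lie within the scatter, so compound 3 holds no separate rank in this assay on these numbers.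

Next comes compound 4 `COc1cccc(NC2=CC(=O)c3c(nc4n3[C@H]3OC[C@@H](O)[C@H]3OC4)C2=O)c1` with 3-methoxyphenyl in place of 2-methoxyphenyl on an amine nitrogen. Among the measured compounds shown here, no measured pair tests this exact exchange. The closest evidence is the pair of steps that replace the phenyl group on that same amine nitrogen, namely a 1.4-fold higher number from compound 2 to compound 3 (0.16 log units; within the scatter) and a 1.9-fold higher number from compound 1 to compound 3 (0.27 log units; within the scatter) with neither going beyond the scatter. The halogen exchange, a 1.3-fold higher number from compound 1 to compound 2 (0.11 log units; within the scatter) as its measured size, also stays within the scatter.

On this evidence no step beyond the scatter is expected, and no direction is favoured. The middle of the estimate is therefore placed among the three measured values. The estimate means a 1.4-fold lower number from compound 3 to compound 4 (0.13 log units; within the scatter) as the expected step, which is within the scatter. Compound 4 is estimated at 5500 nM with 2800 nM to 11000 nM as the expected range.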

Compound 4, half-maximal inhibitory concentration: > 8000 nM
Compound 4 ended at the assay's limit (the forecaster's own chance of this, stated with the estimate: 3%); at least 1.4-fold (0.16 log units) between middle value and limit.
By their numbers in this assay, from the lowest: compounds 1, 2 and 3 (each within the scatter of the next). At a limit, above all of these: compound 4.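

In this assay, among the compounds shown here, compound 4 gives > 8000 nM, a limit of the assay and not a number, which makes it the first reading without a middle value: the limit of > 8000 nM in this assay, at which 1 of the 4 values shown sits. Read as floors only, an at least 1.0-fold higher number from compound 3 to compound 4 (0.03 log units; that floor lies within the scatter), an at least 1.5-fold higher number from compound 2 to compound 4 (0.18 log units; that floor lies within the scatter) and an at least 1.9-fold higher number from compound 1 to compound 4 (0.29 log units; that floor lies within the scatter) do not separate compound 4 from the other three compounds on these numbers. For the compounds shown here, the exchange of (2-methoxyphenyl)amino for (3-methoxyphenyl)amino is the first at this position that keeps the same atoms and the same counts and alters only how they are joined, and its true size is bounded on one side alone.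

From the compounds shown here alone, how far the value of compound 4 lies past the limit stays open, and with it whether 3-methoxyphenyl differs from 2-methoxyphenyl by more than the scatter. Also open, going by these compounds, is how an unsubstituted phenyl on the same amine nitrogen, or a longer chain such as ethoxy in place of methoxy, would read in this assay.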